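Pyridin-2-yl replaces 2,4-dimethoxyphenyl: what to expect

The compounds below may be only part of what the source reports. "The series", "measured", "known", "first", "only" and "open" are said of these compounds alone.

In an ADME assay on Vero cells (Chlorocebus sabaeus) for cytotoxicity, read by MTT assay, with a stated time of 96 h (a lower number here means that less compound is tolerated, a higher number that more compound is tolerated), compound 3 `COc1ccc(-c2nc3cc(/C(C)=N/NC(N)=S)ccc3n2C2CCCCC2)c(OC)c1` gives 20000 nM, level with compound 1 `C/C(=N\NC(N)=S)c1ccc2c(c1)nc(-c1ccccc1)n2C1CCCCC1` at 20000 nM. Compound 2 `C/C(=N\NC(N)=S)c1ccc2c(c1)nc(-c1ccc(C(F)(F)F)cc1)n2C1CCCCC1` gives > 100000 nM, which is a limit of the assay and not a number. Compound 4 `C/C(=N\NC(N)=S)c1ccc2c(c1)nc(-c1ccccn1)n2C1CCCCC1` carries pyridin-2-yl in place of 2,4-dimethoxyphenyl on an aromatic carbon. Two measured steps changed this same aryl group. Exchanging phenyl for 2,4-dimethoxyphenyl gave no change at the digits printed from compound 1 to compound 3 (within the scatter), while adding trifluoromethyl gave an at least 5.0-fold higher number from compound 1 to compound 2 (0.69 log units; beyond the scatter). The new group has no trifluoromethyl, so the first step is the closer guide, and no shift beyond the scatter is expected: no change at the digits printed from compound 3 to compound 4 (within the scatter). Compound 4 is estimated at 20000 nM, with an expected range of 6000 nM to 70000 nM.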

Compound 4, half-maximal cytotoxic concentration: 20000 nM
The estimate for compound 4 equals the measured number at the digits printed; the range from low to high includes it.
By their numbers in this assay, from the lowest: compounds 1, 3 and 4 (each within the scatter of the next). At a limit, above all of these: compound 2.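

In this assay the swap to pyridin-2-yl, which puts a ring nitrogen into the aryl group, gives no change at the digits printed from compound 3 to compound 4 (within the scatter) and no change at the digits printed from compound 1 to compound 4 (within the scatter) as well, so this nitrogen leaves the read-out where the two carbon-only rings put it. The 4-(trifluoromethyl)phenyl group remains the only one here that stands apart, with an at least 5.0-fold lower number from compound 2 to compound 4 (0.69 log units; beyond the scatter) in this set. Compound 2 gives > 100000 nM, a limit of the assay and not a number: the limit of > 100000 nM in this assay, at which 1 of the 4 values shown sits.

Going by these compounds, how large that gap really is stays open. Also open, on these data alone, is whether an amine or a carboxylic acid on this aryl ring would move the number as trifluoromethyl did.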